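Moving the halogen on the benzyl group of compound 3

The compounds below may be only part of what the source reports. "The series", "measured", "known", "first", "only" and "open" are said of these compounds alone.

Compound 3 `Cc1ccc(NC(=S)NC(=O)c2ccc(OCc3cccc(F)c3)cc2)cc1-c1nc2ccccc2[nH]1` is the weakest of the three measured compounds: in a functional assay on MNK45 cells (Homo sapiens) for inhibition, read by MTT assay, with a stated time of 48 h (on this read-out lower numbers stand for stronger inhibition and higher numbers for weaker inhibition), compound 3 gives 86800 nM. Compound 1 `Cc1ccc(NC(=S)NC(=O)c2ccc(OCc3cccc(C(F)(F)F)c3)cc2)cc1-c1nc2ccccc2[nH]1` gives 6050 nM and compound 2 `Cc1ccc(NC(=S)NC(=O)c2ccc(OCc3ccccc3F)cc2)cc1-c1nc2ccccc2[nH]1` gives 2420 nM. Compound 4 `Cc1ccc(NC(=S)NC(=O)c2ccc(OCc3ccccc3Cl)cc2)cc1-c1nc2ccccc2[nH]1` differs from compound 3 by 2-chlorophenyl in place of 3-fluorophenyl on a saturated chain carbon bound to an oxygen on an aromatic ring. The closest guide is the step of a 36-fold higher number from compound 2 to compound 3 (1.55 log units; beyond the scatter), which shows that placing the fluorine on the 2-position of this phenyl ring rather than the 3-position gave a much lower number; compound 4 carries chlorine rather than fluorine at that 2-position, so the size of the gain is uncertain. A large drop is expected, a 22-fold lower number from compound 3 to compound 4 (1.34 log units; beyond the scatter), and compound 4 is estimated at 4000 nM, most likely between 800 nM and 25000 nM.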

Compound 4, half-maximal inhibitory concentration: 51400 nM
Estimate against measurement, compound 4: 13-fold (1.11 log units) below; the whole stated range lies below it.
By their numbers in this assay, from the lowest: compound 2; then compound 1; then compounds 4 and 3 (each within the scatter of the next).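

In this assay, the low number of the 2-fluorophenyl compound does not carry over to chlorine at the same place: chloro in place of fluoro gives a 21-fold higher number from compound 2 to compound 4 (1.33 log units; beyond the scatter) and so undoes nearly all of the gain that fluorine showed there. Compound 4 instead reads level with the 3-fluorophenyl compound (a 1.7-fold lower number from compound 3 to compound 4 (0.23 log units; within the scatter)), while the 3-(trifluoromethyl)phenyl compound keeps a clear edge (an 8.5-fold higher number from compound 1 to compound 4 (0.93 log units; beyond the scatter)). Nothing measured here explains this sensitivity to a single halogen.

Still open, going by these compounds, is how 2-bromophenyl or 3-chlorophenyl would read in this assay, and whether plain phenyl would sit nearer compound 2 or compound 4.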